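The compounds below may be only part of what the source reports. "The series", "measured", "known", "first", "only" and "open" are said of these compounds alone.

Compound 1 `Cn1c(-c2cccnc2)nc2ccc(F)cc21` was tested in an assay on V79 cells for inhibition of cytochrome P450 11B2, mitochondrial (Homo sapiens), read by HTRF, with a stated time of 1 h (on this read-out higher numbers stand for weaker inhibition and lower numbers for stronger inhibition), where compound 1 gives 12 nM. For the measured compounds named here, that is the lower of the two numbers measured so far; compound 2 `Fc1cccc2nc(-c3cccnc3)n(C3CC3)c12` gives 107 nM in this assay, a higher number beyond the usual scatter, though compound 2 differs from compound 1 in more than one place. Compound 3 `Fc1ccc2nc(-c3cccnc3)n(C3CC3)c2c1` differs from compound 1 in one place: cyclopropyl in place of methyl on an aromatic nitrogen. No single-change comparison shows what this swap does on its own. The expected step is a 3.3-fold higher number from compound 1 to compound 3 (0.52 log units; beyond the scatter), a modest move toward a weaker value. Compound 3 is estimated at 40 nM in this assay, within 10 nM to 150 nM.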

Compound 3, half-maximal inhibitory concentration: 4 nM
For compound 3 the middle estimate is 10-fold (1.00 log units) above the measured one; measured number below the stated range.
By their numbers in this assay, from the lowest: compound 3; then compound 1; then compound 2.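

At this aromatic nitrogen, cyclopropyl can stand in place of methyl without loss: in this assay the swap gives a 3.0-fold lower number from compound 1 to compound 3 (0.48 log units; beyond the scatter) and so moves toward stronger inhibition. For the compounds shown here, this is the first single-change comparison at this position, and it shows that two more carbon atoms and a ring here can go with a lower number. Nothing at hand explains the gain.
On these data alone, whether an ethyl group, a longer chain or an amine on this nitrogen would lower the number further stays open.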